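This account rests on a few compounds, and the source may have more. Where it says the series, first, only, none or still open, it means among the compounds named here.

Compound 1 `CC(C)=CCC/C(C)=C\C=N/NC(=O)Nc1nnc(-c2ccc(C)cc2)o1`: in a functional assay on the whole organism (strain albino) with Mus musculus as the target, in the maximal electroshock model, with a stated time of 4 h (a lower number here means that less compound is needed, a higher number that more compound is needed for the effect), compound 1 gives 300 mg/kg.
Compound 2 `CC(C)=CCC/C(C)=C\C=N/c1nnc(-c2ccccc2)o1`: in this assay compound 2 gives 100 mg/kg.
Compound 3 `CC(C)=CCC/C(C)=C\C=N/NC(=O)Nc1nnc(-c2ccccc2)o1`: in this assay compound 3 gives 300 mg/kg.

Compound 2 stands at the lowest number of the three, so the least of it is needed for the effect; its distance to compound 1 and to compound 3 lies beyond the scatter in each case. Compound 4 `CC(C)=CCC/C(C)=C\C=N/c1nnc(-c2ccc(Cl)cc2)o1` differs from compound 2 in a single place: chloro in place of hydrogen on an aromatic carbon. Among the compounds with values here, only one measured step bears on this, since it is also a swap of one group on an aromatic carbon of the six-membered ring of carbon only: no change at the digits printed from compound 1 to compound 3 (within the scatter). That swap of methyl for hydrogen left the number where it was, so a small group on that ring has so far not moved the result. On that basis no step beyond the scatter is expected in this assay, that is no change at the digits printed from compound 2 to compound 4 (within the scatter). For compound 4 the estimated value is 100 mg/kg, with a range from 50 mg/kg to 200 mg/kg.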

Compound 4, minimum effective dose: 300 mg/kg
Compound 4: the middle estimate sits 3.0-fold (0.48 log units) below what was measured; measured number above the stated range.
By their numbers in this assay, from the lowest: compound 2; then compounds 1, 3 and 4 (each within the scatter of the next).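

Placing chloro on the aromatic carbon para to a large group gives a 3.0-fold higher number from compound 2 to compound 4 (0.48 log units; beyond the scatter) in this assay, so more compound is needed for the effect and this position does respond to a change. The earlier swap between methyl and hydrogen, made on a different pair of compounds, gave no change at the digits printed from compound 1 to compound 3 (within the scatter), so that quiet result does not hold for every group or every pair. Nothing available here explains why chloro moves the number.

On these data alone, it remains open whether the step belongs to chloro itself or would also appear with another group at this place, such as fluoro, methoxy or an amine. As far as these compounds go, it is also open whether chloro would act the same way on compound 3, which differs from compound 2 elsewhere in the molecule.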